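Fluoro to hydrogen on the benzyl group of compound 1

The source may report more compounds than this note shows. Statements on the series, on what has been measured and on what is new or still open speak of the compounds shown alone.

Compound 1 `O=C(O)C[C@H](O)C[C@H](O)CCn1c(-c2ccc(F)cc2)nc(C(=O)NCc2ccccc2F)c1C1CC1` is measured in an assay on microsomes from liver for inhibition of 3-hydroxy-3-methylglutaryl-coenzyme A reductase (Rattus norvegicus), read by scintillation counting, with stated times of 0.5 h and 0.75 h (a higher number here means a weaker inhibitor, a lower number a stronger inhibitor), and gives 1.5 nM. Among the three numbers shown it stands second highest; its nearest neighbour is compound 2 `O=C(O)C[C@H](O)C[C@H](O)CCn1c(-c2ccc(F)cc2)nc(C(=O)NCc2ccc(F)c(F)c2)c1C1CC1`, which gives 1.2 nM, and the furthest is compound 3 `CN(C)S(=O)(=O)c1ccc(CNC(=O)c2nc(-c3ccc(F)cc3)n(CC[C@@H](O)C[C@@H](O)CC(=O)O)c2C2CC2)cc1`, which gives 4.9 nM. The step of a 1.3-fold lower number from compound 1 to compound 2 (0.10 log units; within the scatter) moves the fluoro substitution around on the ring bound to the amide-type nitrogen without a change beyond the scatter. The step of a 3.3-fold higher number from compound 1 to compound 3 (0.51 log units; beyond the scatter) and the step of a 4.1-fold higher number from compound 2 to compound 3 (0.61 log units; beyond the scatter) show that a much larger group on that ring costs a modest amount.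

Compound 4 `O=C(O)C[C@H](O)C[C@H](O)CCn1c(-c2ccc(F)cc2)nc(C(=O)NCc2ccccc2)c1C1CC1` is not yet measured. It differs from compound 1 by hydrogen in place of fluoro on an aromatic carbon. Within the data shown here, no measured step removes a fluoro from this ring outright, so the bearing is indirect. The step from compound 1 to compound 2 suggests that the pattern of fluoro on this ring matters little, while the steps to compound 3 show that only a substantial change of the group produces a clear shift. A step within the scatter, or a slightly higher number, is therefore expected: a 1.3-fold higher number from compound 1 to compound 4 (0.12 log units; within the scatter). For compound 4 the estimated value in this assay is 2 nM, with a range from 1 nM to 4.5 nM.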

Compound 4, half-maximal inhibitory concentration: 1.4 nM
Estimate against measurement, compound 4: 1.4-fold (0.15 log units) above; the measured number falls inside the stated range.
By their numbers in this assay, from the lowest: compounds 2, 4 and 1 (each within the scatter of the next); then compound 3.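

In this assay, taking the fluoro off the ring altogether gives a 1.1-fold lower number from compound 1 to compound 4 (0.03 log units; within the scatter), and the comparison with the difluorinated analogue gives a 1.2-fold higher number from compound 2 to compound 4 (0.07 log units; within the scatter), so no fluoro is required on this benzyl ring among the compounds shown, whether 2-fluorophenyl or 3,4-difluorophenyl is the comparator. Among these compounds, the plain benzyl amide also gives a direct reference for the one compound that stands apart, with hydrogen in place of dimethylsulfamoyl giving a 3.5-fold lower number from compound 3 to compound 4 (0.54 log units; beyond the scatter), which places the shift on the dimethylsulfamoyl group itself rather than on the absence of fluoro from compound 3. No measurement in hand accounts for the flat response to fluoro on this ring.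

Still open, on these data alone, is whether smaller groups on the ring, such as methyl, methoxy or nitrile, stay with compounds 1, 2 and 4 or move towards compound 3, and whether an amine or a carboxylic acid there behaves like dimethylsulfamoyl. Also open, as far as these compounds go, is whether the phenyl ring is needed at all, which a simple alkyl amide such as the methyl amide in place of the benzyl amide would address.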